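A few compounds are considered here, and "the series" means these few. Any claim that something is new, unique, unknown or untested is made for them only; others in the source may bear on it.

Compound 1 `Cc1ccccc1-n1nc(C)c2c1NC(=O)[C@H](C)S[C@@H]2c1ccc(Oc2ccccc2)cc1` gives 1300 nM.
Compound 2 `COC(=O)c1cccc(-c2ccc([C@H]3S[C@@H](C)C(=O)Nc4c3c(C)nn4-c3ccccc3C)cc2)c1` gives "not active" (no number reported).
Compound 3 `Cc1ccccc1-n1nc(C)c2c1NC(=O)[C@H](C)S[C@@H]2c1ccc(-c2ccsc2)cc1` gives 1400 nM.

In an assay on isolated protein for agonist activity at Bile acid receptor (Homo sapiens), read by AlphaScreen, with a stated time of 30 min (on this read-out lower numbers stand for an effect already at smaller amounts and higher numbers for an effect only at larger amounts of compound), compound 3 gives 1400 nM, and compound 1 gives 1300 nM; the two numbers sit within the usual scatter of each other, so compound 3 is set apart from compound 1 only nominally. Compound 2 returned no number in this assay. Among the measured compounds shown here, the one step recorded between compounds that differ in a single place is a 1.1-fold higher number from compound 1 to compound 3 (0.03 log units; within the scatter), and it stays within the scatter.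

Compound 4 `COc1cccc(Oc2ccc([C@H]3S[C@@H](C)C(=O)Nc4c3c(C)nn4-c3ccccc3C)cc2)c1` differs from compound 3 in one place: 3-methoxyphenoxy in place of thiophen-3-yl on an aromatic carbon. The entering group shares the phenoxy part of compound 1, and the single-change step from compound 1 to compound 3 was within the scatter, so the data give no reason to expect a shift in either direction here. For the measured compounds named here, no step or difference relates compound 2 to the others; its outcome shows only that one member of this set gave no number at all.

The expectation for compound 4 is therefore a number near that of compound 3, no change at the digits printed from compound 3 to compound 4 (within the scatter), with no change beyond the scatter. Compound 4 is estimated at 1400 nM, in a range from 600 nM to 4000 nM.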

Compound 4, half-maximal effective concentration: 1700 nM
Compound 4: middle estimate off by 1.2-fold (0.08 log units), on the low side; measured number inside the range.
By their numbers in this assay, from the lowest: compounds 1, 3 and 4 (each within the scatter of the next).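

In this assay the exchange of thiophen-3-yl, with 5 heavy atoms, for 3-methoxyphenoxy, with 9 heavy atoms, on an aromatic carbon para to a large group gives a 1.2-fold higher number from compound 3 to compound 4 (0.08 log units; within the scatter) and so stays within the scatter, as did the earlier exchange of phenoxy for thiophen-3-yl at this position. The second change is new in kind, since it alters the phenoxy group itself rather than replacing it: methoxy in place of hydrogen on an aromatic carbon gives a 1.3-fold higher number from compound 1 to compound 4 (0.12 log units; within the scatter) and also stays within the scatter, so compounds 1, 3 and 4 are not told apart by this read-out. No measurement shown here offers an explanation for why these changes leave the number within the scatter.

Going by these compounds, whether an amine or a carboxylic acid in place of the methoxy would move the number beyond the scatter remains open. Among the compounds shown here, also open is what sets apart compound 2, which gave "not active" (no number reported) in this assay and is the only compound here without a number, since no single-place step links it to the others.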